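One Methoxy Fewer: What to Expect of Compound 3

The compounds below may be only part of what the source reports. "The series", "measured", "known", "first", "only" and "open" are said of these compounds alone.

In an ADME assay on Vero cells (Chlorocebus sabaeus) for cytotoxicity, read by MTT assay, with a stated time of 72 h (on this read-out lower numbers stand for higher toxicity in this test and higher numbers for lower toxicity in this test), compound 1 `COc1ccc([C@H](O)COC(=O)/C=C/c2ccccc2)cc1OC` gives 24300 nM and compound 2 `COc1cccc([C@H](O)COC(=O)/C=C/c2ccccc2)c1` gives 61900 nM. Compound 2 therefore holds the higher of the two numbers, which means lower toxicity in this test, and the gap between them lies beyond the usual scatter.

The next compound, compound 3 `O=C(/C=C/c1ccccc1)OC[C@@H](O)c1ccccc1`, has not yet been measured. It differs from compound 2 by a single change: hydrogen in place of methoxy on an aromatic carbon, which is hydrogen in place of methoxy on an aromatic carbon. The same kind of change has been measured only once, in the modest step of a 2.5-fold higher number from compound 1 to compound 2 (0.41 log units; beyond the scatter), which goes beyond the scatter. A single step cannot establish a trend, and the data do not show whether it will repeat. Even so, it is the only guide available, so a step of similar size and in the same direction is expected in this assay. The estimated step is a 2.0-fold higher number from compound 2 to compound 3 (0.31 log units; beyond the scatter). For compound 3 the expected value is 125000 nM, with an estimated range from 50000 nM to 300000 nM.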

Compound 3, half-maximal cytotoxic concentration: 39200 nM
Estimate against measurement, compound 3: 3.2-fold (0.50 log units) above; the measured number lies below the stated range.
By their numbers in this assay, from the lowest: compounds 1, 3 and 2 (each within the scatter of the next, the first and the last beyond it).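

In this assay, putting hydrogen in place of methoxy at this place, on an aromatic carbon meta to a large group, gives a 1.6-fold lower number from compound 2 to compound 3 (0.20 log units; within the scatter) and so leaves compound 2 and compound 3 indistinguishable in this test. The same kind of exchange elsewhere in the series gave a 2.5-fold higher number from compound 1 to compound 2 (0.41 log units; beyond the scatter) and so stood clear of the scatter, which means that this exchange does not carry one fixed size across these compounds and that what it does depends on where the methoxy group sits. No measurement accompanies these numbers that could account for the contrast between the two steps.

The compounds shown carry only methoxy or hydrogen at this place, so it remains open whether a fluorine atom, a hydroxyl group, an amine or a longer chain such as ethoxy would give a number clearly apart from that of compound 2. Also open, as far as these compounds go, is whether the contrast between the two steps would hold on a different core or in another kind of cell.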